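Halogen swap on the aniline ring of a hydroxamate

The source may report more compounds than this note shows. Statements on the series, on what has been measured and on what is new or still open speak of the compounds shown alone.

Compound 1, `O=C(CCCCCCn1cc(Nc2ncc(Cl)c(Nc3ccc(F)cc3)n2)cn1)NO`, gives 120 nM in a functional assay on Jurkat cells (Homo sapiens) for antiproliferative activity, read by MTT assay, with a stated time of 48 h; a higher number here means a weaker inhibitor, a lower number a stronger inhibitor.
Compound 2, `O=C(CCCCCn1cc(Nc2ncc(Cl)c(Nc3ccc(F)cc3)n2)cn1)NO`, gives 60 nM in this assay.

Compound 1 stands with the highest of the two numbers in this assay; its nearest neighbour is compound 2, with a 2.0-fold lower number from compound 1 to compound 2 (0.30 log units; within the scatter). The unmeasured compound 3, `O=C(CCCCCCn1cc(Nc2ncc(Cl)c(Nc3ccc(Cl)cc3)n2)cn1)NO`, differs from compound 1 by chloro in place of fluoro on an aromatic carbon. For the measured compounds named here, no measured step touches this position: the only recorded step concerns the chain, not the ring. For compound 3 in this assay no step beyond the scatter is therefore expected, as a 1.1-fold lower number from compound 1 to compound 3 (0.04 log units; within the scatter). Compound 3 is estimated at 110 nM, between 50 nM and 250 nM.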

Compound 3, half-maximal inhibitory concentration: 100 nM
Compound 3: the middle estimate sits 1.1-fold (0.04 log units) above what was measured; low and high end bracket the measured number.
By their numbers in this assay, from the lowest: compounds 2, 3 and 1 (each within the scatter of the next).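

In this assay, the change from 4-fluorophenyl to 4-chlorophenyl gives a 1.2-fold lower number from compound 1 to compound 3 (0.08 log units; within the scatter). This is the first change on the aromatic ring among these compounds, and it shows that chloro can stand in for fluoro at this position, para to a large group, without a step beyond the scatter. Nothing shown here accounts for this result.

On these data alone, it remains open whether hydrogen, bromo, methoxy or an amine at this position would also stay within the scatter. As far as these compounds go, it also remains open whether chloro would behave alike on the shorter chain of compound 2.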